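The source may report more compounds than this note shows. Statements on the series, on what has been measured and on what is new or still open speak of the compounds shown alone.

Going by the values given here, compound 1 `O=C(CCC1=CCN(CCCc2ccc(Cl)cc2)C1=O)NO` is one of three compounds measured in a functional assay on NCI-H23 cells (Homo sapiens) for inhibition, read by sulforhodamine B assay (on this read-out higher numbers stand for weaker inhibition of growth and lower numbers for stronger inhibition of growth), where compound 1 gives 2520 nM. Compound 2 `Cc1ccccc1CCCN1CC=C(CCC(=O)NO)C1=O` gives 2520 nM in this assay, and compound 3 `Cc1cccc(CCCN2CC=C(CCC(=O)NO)C2=O)c1` gives 2520 nM, so compound 1 stands level with both at the digits shown; its nearest neighbour is compound 2 and its furthest is compound 3, and neither gap goes beyond the scatter. Three steps among these compounds are known: no change at the digits printed from compound 1 to compound 2 (within the scatter), with 2-methylphenyl in place of 4-chlorophenyl on a saturated chain carbon, three bonds along the chain from an amide-type nitrogen in a ring; no change at the digits printed from compound 1 to compound 3 (within the scatter), with 3-methylphenyl in place of 4-chlorophenyl at the same place; and no change at the digits printed from compound 2 to compound 3 (within the scatter). Every exchange of the aryl group tried so far left the growth inhibition where it was.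

Compound 4 `CC(C)c1ccc(CCCN2CC=C(CCC(=O)NO)C2=O)cc1` differs from compound 1 by isopropyl in place of chloro on an aromatic carbon, on an aromatic carbon of a six-membered aromatic ring of carbon only, para to a large group. Among the compounds with values here, no measured step tests isopropyl itself, and the three known steps all show no change; the closest bearing is no change at the digits printed from compound 1 to compound 2 (within the scatter) and no change at the digits printed from compound 1 to compound 3 (within the scatter), both flat. Compound 4 is therefore expected to give 2520 nM, with a range from 1100 nM to 5800 nM. For compound 4 this estimate means an expected step of no change at the digits printed from compound 1 to compound 4 (within the scatter), no change beyond the scatter.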

Compound 4, concentration for 50% growth inhibition: 2520 nM
For compound 4 middle estimate and measured number coincide at the digits printed, and the stated range covers the measured number.
By their numbers in this assay, from the lowest: compounds 1, 2, 3 and 4 (each within the scatter of the next).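

In this assay, isopropyl in place of chloro on an aromatic carbon, para to a large group, brings no change at the digits printed from compound 1 to compound 4 (within the scatter). The earlier steps shown here went to 2-methylphenyl and 3-methylphenyl, so they changed the place of the substituent along with the group; this step keeps the place and exchanges the group alone, with 3 heavy atoms entering for 1 heavy atom, and the number still holds. No evidence is available on what lies behind this flat result.

All the aryl substituents shown are chloro, methyl or isopropyl, with no hydrogen-bond donors or acceptors among them, so it stays open whether an amine or a carboxylic acid at this position, or a longer chain between the aromatic ring and the amide-type nitrogen, would shift the growth inhibition away from the level shared by all four compounds. The hydroxamic acid and the shared core are the same throughout, so the compounds shown also say nothing about how the read-out responds to a change in either of them.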